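Removing One Chloro From The Sulfonyl Aryl Ring

A few compounds are considered here, and "the series" means these few. Any claim that something is new, unique, unknown or untested is made for them only; others in the source may bear on it.

Compound 1 `Cc1ccc2ncc(S(=O)(=O)c3ccc(Cl)cc3)c(N3CCC(C)CC3)c2c1` gives 79% in an assay on isolated protein for displacement of a labelled ligand from metabotropic glutamate receptor 5 (Homo sapiens), with a stated time of 60 min, tested at 1 uM; a lower number here means less inhibition, a higher number more inhibition at the concentration tested (going by the name of the read-out).
Compound 2 `Cc1ccc2ncc(S(=O)(=O)c3ccccc3)c(N3CCC(C)CC3)c2c1` gives 67% in this assay.
Compound 3 `Cc1ccc2ncc(S(=O)(=O)c3cc(Cl)cc(Cl)c3)c(N3CCC(C)CC3)c2c1` gives 75% in this assay.

Compound 3 stands second highest of the three numbers; its nearest neighbour is compound 1, and the step of a number 4 percentage points lower from compound 1 to compound 3 (within the scatter) sits within the scatter, while a number 8 percentage points higher from compound 2 to compound 3 (within the scatter) also stays within it. The new compound 4 `Cc1ccc2ncc(S(=O)(=O)c3cccc(Cl)c3)c(N3CCC(C)CC3)c2c1` is not yet measured in this assay. The change from compound 3 to compound 4 is hydrogen in place of chloro on an aromatic carbon. Within the data shown here, one measured step bears directly on this kind of change: a number 12 percentage points lower from compound 1 to compound 2 (beyond the scatter), a modest loss beyond the scatter when a chloro on the sulfonyl aryl ring is replaced by hydrogen. On the other hand, compound 2, which carries no chloro at all, and compound 3 differ only within the scatter. Compound 4 keeps one chloro, so it is expected to sit between compound 2 and compound 3, with a step of a number 3 percentage points lower from compound 3 to compound 4 (within the scatter) that is expected to stay within the scatter. Compound 4 is therefore estimated at 72%, with a range from 60% to 82%.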

Compound 4, a percentage reported as inhibition, at one concentration (the size of the read-out at that concentration, not a potency): 91%
Compound 4: middle estimate off by 19 percentage points, on the low side; the measured number lies above the stated range.
By their numbers in this assay, from the lowest: compounds 2, 3 and 1 (each within the scatter of the next, the first and the last beyond it); then compound 4.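

Among these compounds, the replacement of chloro by hydrogen on the sulfonyl aryl ring has no single direction in this assay, for here it gives a number 16 percentage points higher from compound 3 to compound 4 (beyond the scatter), the opposite sign to the earlier step: the same change on two cores in this assay, a number 12 percentage points lower (beyond the scatter) from compound 1 to compound 2 and a number 16 percentage points higher (beyond the scatter) from compound 3 to compound 4, 28 percentage points apart, beyond the scatter of two such steps The place of a lone chloro also matters, as 3-chlorophenyl in place of 4-chlorophenyl gives a number 12 percentage points higher from compound 1 to compound 4 (beyond the scatter), a difference the earlier compounds could not show. With a number 24 percentage points higher from compound 2 to compound 4 (beyond the scatter), 3-chlorophenyl also stands clear of plain phenyl, a gap that 3,5-dichlorophenyl did not open.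

The compounds shown leave open whether this step belongs to chloro itself or would also appear with fluoro, methoxy or a nitrile in that place. They also leave open whether it carries over when an ethyl group takes the place of the methyl on the shared core.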